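Swapping the sulfonyl aryl group for a bromophenyl

The source may report more compounds than this note shows. Statements on the series, on what has been measured and on what is new or still open speak of the compounds shown alone.

Compound 1 `COc1ccc(-c2cc(=O)c3c(OC)cc(OC)cc3n2S(=O)(=O)c2c(F)c(F)c(F)c(F)c2F)cc1` and compound 2 `COc1ccc(-c2cc(=O)c3c(OC)cc(OC)cc3n2S(=O)(=O)c2cc(Cl)cc(Cl)c2O)cc1` share one core and differ only in the ring on the sulfonyl sulfur. In a functional assay on KOPN-8 cells (Homo sapiens) for antiproliferative activity, with a stated time of 72 h (on this read-out higher numbers stand for an effect only at larger amounts of compound and lower numbers for an effect already at smaller amounts), compound 1 gives > 34400 nM, which is a limit of the assay. In this assay compound 2 likewise reaches only a limit, > 37900 nM. The step that the two limits leave unreadable from compound 1 to compound 2 therefore cannot be read. Compound 3 `COc1ccc(-c2cc(=O)c3c(OC)cc(OC)cc3n2S(=O)(=O)c2ccc(Br)cc2)cc1` carries 4-bromophenyl in place of 3,5-dichloro-2-hydroxyphenyl on a sulfonyl sulfur. Because both measured values sit at limits the limit of > 34400 nM in this assay, at which 1 of the 2 values shown sits (the limit of > 37900 nM in this assay, at which 1 of the 2 values shown sits), no readable step bears on this change. Compound 3 is expected near 40000 nM, between 8000 nM and 150000 nM, an estimated step that the limit leaves unreadable from compound 2 to compound 3.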

Compound 3, half-maximal effective concentration: > 86200 nM
Compound 3 gave a limit, no number; the forecaster's own chance of this, stated with the estimate: 75%; middle value at least 2.1-fold (0.33 log units) from the limit.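

In this assay, within the data shown here, compound 1, compound 2 and compound 3 each give only a limit, not a number, so no step among them can be read. The compounds shown leave open whether any ring on the sulfonyl sulfur gives a measurable effect in this assay.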